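Esterifying One Hydroxyl of Compound 2 with a Branched Acyl Group

The source may report more compounds than this note shows. Statements on the series, on what has been measured and on what is new or still open speak of the compounds shown alone.

Of the compounds shown here, three have so far been tested in a functional assay on AGS cells (Homo sapiens) for cytotoxicity, read by trypan blue exclusion, with a stated time of 24 h; a higher number here means a weaker inhibitor, a lower number a stronger inhibitor. Compound 1 `C=C1C(=O)O[C@@H]2CC(C)=C([C@@H](C)CCCOC(C)=O)[C@H](OC(C)=O)[C@H]12` carries two acetates, and in this assay compound 1 gives 66400 nM. Compound 2 `C=C1C(=O)O[C@@H]2CC(C)=C([C@@H](C)CCCO)[C@H](O)[C@H]12` carries free hydroxyls in place of both acetates. For compound 2 this assay reports no number but only a limit, > 100000 nM. Compound 3 `CC(=O)OCCC[C@H](C)C1=C[C@@H]2[C@H](C)C(=O)O[C@@H]2C[C@@]1(C)O` likewise returns only a limit, > 100000 nM. Compound 2 therefore stands at the weak end of what is shown, at the cut-off of the assay rather than at a measured value, a position it shares with compound 3 (the limit of > 100000 nM in this assay, at which 2 of the 3 values shown sit). Compound 1 alone gives a measured number, and that number sits on the stronger side of the cut-off.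

Compound 4 `C=C1C(=O)O[C@@H]2CC(C)=C([C@@H](C)CCCO)[C@H](OC(=O)C(C)CC)[C@H]12` differs from compound 2 in one place: (sec-butyl)carbonyl in place of hydrogen on an oxygen on a saturated carbon. Among the measured compounds shown here, no measured pair differs in a single place, so the size of the step cannot be read from data; the author expects only a small move toward a measurable number, in the direction compound 1 points with 66400 nM, with the step of an at least 1.6-fold lower number from compound 2 to compound 4 (0.22 log units; that floor lies within the scatter) probably not far beyond the scatter. Compound 4 is accordingly expected to give about 60000 nM, between 25000 nM and 150000 nM, with a fair chance that this assay again reports only a limit.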

Compound 4, half-maximal inhibitory concentration: 31300 nM
Estimate against measurement, compound 4: 1.9-fold (0.28 log units) above; measured number inside the range.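

Among the compounds shown here, with compound 4, this oxygen on a saturated carbon gives the first change that can be read on its own: hydroxy to ((sec-butyl)carbonyl)oxy gives an at least 3.1-fold lower number from compound 2 to compound 4 (0.50 log units; beyond the scatter) in this assay, with the other hydroxyl still free. Compound 4 gives 31300 nM as a measured number, so a free primary-chain hydroxyl does not by itself rule out a measured number, and esterifying both hydroxyls is not needed to obtain one. As far as these compounds go, the true size of the step remains unknown, and the printed figure is only its lower bound, since compound 2 is reported only as a limit: the limit of > 100000 nM in this assay, at which 2 of the 4 values shown sit.

Open, from the compounds shown here alone, is how an acetyl, a longer unbranched acyl chain or an acyl group carrying an amine would read on this same oxygen, so the part played by the branch of the sec-butyl group stays undecided. Also open, going by these compounds, is what an ester on the other hydroxyl alone would do in this assay, and whether the two positions add to each other.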